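The source may report more compounds than this note shows. Statements on the series, on what has been measured and on what is new or still open speak of the compounds shown alone.

Three related compounds have been tested in an ADME assay on HEK293 cells (Homo sapiens) for cytotoxicity, read by MTT assay, with a stated time of 72 h; a lower number here means a stronger inhibitor, a higher number a weaker inhibitor. Compound 1 `O=C(CN1CCN(C(=O)c2ccc(Br)cc2)CC1)N1CCN(CCCc2c[nH]c3ccccc23)CC1` gives 71900 nM, and compound 3 `COc1ccc2[nH]cc(CCCN3CCN(C(=O)CN4CCN(C(=O)c5ccc(Cl)cc5)CC4)CC3)c2c1` gives 117000 nM. These two numbers lie within the scatter of each other, so compound 3 cannot be separated from compound 1. Compound 2 `COc1ccc2[nH]cc(CCCN3CCN(C(=O)CN4CCN(C(=O)c5ccccc5)CC4)CC3)c2c1` reads > 200000 nM, which is a limit of the assay and not a number.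

Compound 4 `COc1ccc2[nH]cc(CCCN3CCN(C(=O)CN4CCN(C(=O)c5ccc(Br)cc5)CC4)CC3)c2c1` has not yet been measured. It differs from compound 3 in one place, bromo in place of chloro on an aromatic carbon. The exchange sits on a six-membered aromatic ring of carbon only, para to a large group, and turns 4-chlorophenyl into 4-bromophenyl.

Among the measured compounds shown here, the one measured step at this carbon, chloro in place of hydrogen, was an at least 1.7-fold lower number from compound 2 to compound 3 (0.23 log units; that floor lies within the scatter). For the measured compounds named here, no measured step exchanges one halogen for another. No shift beyond the scatter is therefore expected in this assay, and no direction is favoured, so the expectation stays close to compound 3 at 117000 nM. The estimate amounts to an expected 1.1-fold lower number from compound 3 to compound 4 (0.03 log units; within the scatter). For compound 4 the estimated value is 110000 nM, with an expected range of 60000 nM to 190000 nM.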

Compound 4, half-maximal inhibitory concentration: 80500 nM
Estimate against measurement, compound 4: 1.4-fold (0.14 log units) above; the measured number falls inside the stated range.
By their numbers in this assay, from the lowest: compounds 1, 4 and 3 (each within the scatter of the next). At a limit, above all of these: compound 2.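

In this assay, the 4-chlorophenyl and 4-bromophenyl compounds cannot be told apart, with a 1.5-fold lower number from compound 3 to compound 4 (0.16 log units; within the scatter), so this halogen exchange at the aromatic carbon shows no separable effect. Bromo in place of hydrogen at the same carbon gives the first step at this position that clears the scatter, an at least 2.4-fold lower number from compound 2 to compound 4 (0.39 log units; beyond the scatter), while methoxy in place of hydrogen elsewhere on the aromatic core, with the 4-bromophenyl group kept, gives a 1.1-fold higher number from compound 1 to compound 4 (0.05 log units; within the scatter) and so separates nothing. Compound 2 reads as a limit and not a number, so the hydrogen steps are floors: the limit of > 200000 nM in this assay, at which 1 of the 4 values shown sits.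

The matching chloro step remains unresolved, at an at least 1.7-fold lower number from compound 2 to compound 3 (0.23 log units; that floor lies within the scatter), so the compounds shown do not establish whether chloro, like bromo, stands apart from hydrogen at this carbon. They also leave open how fluoro, iodo, a methoxy group or an amine at this carbon would read in this assay, and whether any such group would give a step beyond the scatter from the 4-bromophenyl compound.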